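The source may hold more compounds than are shown below. What is called first, only, known or untested is meant among the compounds shown, and "the series" means these compounds.

Measured compounds in a functional assay on HT-29 cells (Homo sapiens) for antiproliferative activity, read by sulforhodamine B assay, with a stated time of 48 h; on this read-out lower numbers stand for stronger inhibition and higher numbers for weaker inhibition:
Compound 1 `CN1CCN(c2ccc(S(=O)(=O)Oc3ccc(F)cc3)cc2)C1=O`: a limit of the assay, > 100000 nM.
Compound 2 `CN1CCN(c2ccc(S(=O)(=O)Oc3ccc(Cl)cc3)cc2)C1=O`: 12000 nM.
Compound 3 `CCCN1CCN(c2ccc(S(=O)(=O)Oc3cccc(F)c3)cc2)C1=O`: 18000 nM.

Between compound 1 and compound 2 the change is chloro in place of fluoro on an aromatic carbon, and it gives an at least 8.3-fold lower number from compound 1 to compound 2 (0.92 log units; beyond the scatter); the true size is open at the upper end because compound 1 sits at the limit of > 100000 nM in this assay, at which 1 of the 3 values shown sits. Compound 4 `CCCN1CCN(c2ccc(S(=O)(=O)Oc3cccc(Cl)c3)cc2)C1=O` is not yet measured; it differs from compound 3 by chloro in place of fluoro on an aromatic carbon, the same kind of change, here meta to a large group rather than para to a large group. The difference between the cores of compound 3 and compound 1 is not broken down here. In this assay a smaller step than the earlier one is expected, a 3.0-fold lower number from compound 3 to compound 4 (0.48 log units; beyond the scatter), the earlier one being open-ended because compound 1 sits at the limit of > 100000 nM in this assay, at which 1 of the 3 values shown sits. For compound 4 the estimate is 6000 nM.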

Compound 4, half-maximal inhibitory concentration: 13000 nM
Beside the measured number, compound 4's estimate is 2.2-fold (0.34 log units) below it; low and high end bracket the measured number.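

In this assay, chloro in place of fluoro on an aromatic carbon gives a 1.4-fold lower number from compound 3 to compound 4 (0.14 log units; within the scatter), so the change does not carry over at one size from one core to the other: the same change on two cores in this assay, an at least 8.3-fold lower number (0.92 log units; beyond the scatter) from compound 1 to compound 2 and a 1.4-fold lower number (0.14 log units; within the scatter) from compound 3 to compound 4, at least 6.0-fold (0.77 log units) apart, beyond the scatter of two such steps

As far as these compounds go, compound 1 is a limit of the assay, > 100000 nM, so the earlier step stays open-ended. The two pairs differ both in the core and in where the halogen sits, and these compounds do not show which of the two goes with the gap.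

Open, from the compounds shown here alone, is whether the step on the core of compound 1 would keep its size with the halogen placed as in compound 3, and how a bromo group in place of chloro would read in this assay. Also open, going by these compounds, is what a longer chain on the core would do to these numbers.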